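The source may hold more compounds than are shown below. What is called first, only, known or untested is meant among the compounds shown, and "the series" means these compounds.

Measured in an ADME assay (liver) for metabolic stability, with Liver microsome (Homo sapiens) as the target, using microsomes; a lower number here means that the compound disappears faster, a higher number that the compound lasts longer:
- Compound 1 `CCc1nc2cc(Cl)ccn2c1C(=O)NCc1ccc(-c2ccc(Cl)cc2)cc1`: > 2 h, a limit of the assay and not a number
- Compound 2 `CCc1nc2cc(Cl)ccn2c1C(=O)NCc1ccc(N2CCCCC2)cc1`: 0.22 h
- Compound 3 `CCc1nc2cc(Cl)ccn2c1C(=O)NCc1ccc(N2CCCCCC2)cc1`: 0.0483 h

Compound 3, at 0.0483 h, has the lower of the two actual numbers, and the nearest comparison is compound 2. Compound 4 `CCc1nc2cc(Cl)ccn2c1C(=O)NCc1ccc(N2CC3CCCCC3C2)cc1` changes only the ring group on the aromatic carbon: a group of 9 heavy atoms (8 carbon, 1 nitrogen; one five-membered non-aromatic ring with 1 hetero atom, one six-membered non-aromatic ring of carbon only) in place of a group of 7 heavy atoms (6 carbon, 1 nitrogen; one seven-membered non-aromatic ring with 1 hetero atom), on an aromatic carbon.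

Among the measured compounds shown here, the closest precedent is the exchange of one non-aromatic nitrogen ring for another, a 4.6-fold lower number from compound 2 to compound 3 (0.66 log units; beyond the scatter). The larger steps, an at least 9.0-fold lower number from compound 1 to compound 2 (0.95 log units; beyond the scatter) and an at least 41-fold lower number from compound 1 to compound 3 (1.61 log units; beyond the scatter), replace 4-chlorophenyl and say less about this change. In this assay, a small decrease is therefore expected for the larger group of compound 4, probably not clearly beyond the scatter. The estimated change is a 1.2-fold lower number from compound 3 to compound 4 (0.08 log units; within the scatter). For compound 4 the estimated half-life is 0.04 h, with an expected range from 0.015 h to 0.12 h.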

Compound 4, half-life: 0.248 h
For compound 4 the middle estimate is 6.2-fold (0.79 log units) below the measured one; measured number above the stated range.
By their numbers in this assay, from the lowest: compound 3; then compounds 2 and 4 (each within the scatter of the next). At a limit, above all of these: compound 1.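

In this assay, the step from azepan-1-yl to the group of compound 4, with its five-membered and six-membered non-aromatic rings, goes upward: a 5.1-fold higher number from compound 3 to compound 4 (0.71 log units; beyond the scatter), while the comparison with piperidin-1-yl gives a 1.1-fold higher number from compound 2 to compound 4 (0.05 log units; within the scatter), within the scatter. Among these three nitrogen ring groups, therefore, a larger group does not go with a shorter half-life, and compound 4 goes against the fall seen with compound 3. Against the 4-chlorophenyl group, the new ring group still shows an at least 8.0-fold lower number from compound 1 to compound 4 (0.90 log units; beyond the scatter), and this step is open-ended, as compound 1 stands at a limit of the assay and not a number: the limit of > 2 h in this assay, at which 1 of the 4 values shown sits.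

What the compounds shown leave open is how a morpholine ring, with its ring oxygen, or an open-chain diethylamino group would behave on this aromatic carbon. On these data alone, whether any non-aromatic nitrogen ring here can approach compound 1 also remains open.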